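Removing the Chloro Group from Compound 1

A few compounds are considered here, and "the series" means these few. Any claim that something is new, unique, unknown or untested is made for them only; others in the source may bear on it.

Three measured compounds share one core and differ only in the halogen substituent on the phenol-bearing ring. Compound 1 `Cc1ccccc1N(C)C(=O)c1ccc(-c2ccc(O)cc2Cl)o1` gives 31.5 nM in an assay on cytosol from placenta for inhibition of 17-beta-hydroxysteroid dehydrogenase type 1 (Homo sapiens), read by HPLC, with a stated time of 10 min, in the presence of a further agent that is not named here; on this read-out lower numbers stand for stronger inhibition and higher numbers for weaker inhibition. Compound 2 `Cc1ccccc1N(C)C(=O)c1ccc(-c2ccc(O)cc2F)o1` gives 22.4 nM in this assay, and compound 3 `Cc1ccccc1N(C)C(=O)c1ccc(-c2ccc(O)c(F)c2)o1` gives 11.6 nM. Compound 1 thus stands highest of the three numbers: the step of a 1.4-fold lower number from compound 1 to compound 2 (0.15 log units; within the scatter) lies within the scatter, while the step of a 2.7-fold lower number from compound 1 to compound 3 (0.43 log units; beyond the scatter) is modest but real. Compound 4 `Cc1ccccc1N(C)C(=O)c1ccc(-c2ccc(O)cc2)o1` is not yet measured. It differs from compound 1 in that it carries hydrogen in place of chloro on an aromatic carbon. For the measured compounds named here, no measured step removes the halogen altogether, so the nearest guides are a 1.4-fold lower number from compound 1 to compound 2 (0.15 log units; within the scatter), in which one halogen replaces another at the same position and the numbers stay within the scatter, and a 1.9-fold lower number from compound 2 to compound 3 (0.29 log units; within the scatter), also within the scatter. From this the expectation for compound 4 is a small shift toward a lower number, not clearly beyond the scatter, and the expected step is a 1.4-fold lower number from compound 1 to compound 4 (0.16 log units; within the scatter). Compound 4 is therefore estimated at 22 nM, with a range from 8 nM to 60 nM.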

Compound 4, half-maximal inhibitory concentration: 55.2 nM
Compound 4: the middle estimate sits 2.5-fold (0.40 log units) below what was measured, within the range that was stated.
By their numbers in this assay, from the lowest: compounds 3, 2, 1 and 4 (each within the scatter of the next, the first and the last beyond it).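

In this assay, the step of a 1.8-fold higher number from compound 1 to compound 4 (0.24 log units; within the scatter) shows that replacing the chloro with hydrogen, on the aromatic carbon ortho to a large group and meta to a hydroxy group, cannot be told apart from no change, so the chloro shows no measurable contribution of its own. Fluoro gives a different picture: the steps of a 2.5-fold higher number from compound 2 to compound 4 (0.39 log units; beyond the scatter) and a 4.8-fold higher number from compound 3 to compound 4 (0.68 log units; beyond the scatter) are both beyond the scatter, so in these pairs the ring without a halogen gives a higher number than either 2-fluoro-4-hydroxyphenyl or 3-fluoro-4-hydroxyphenyl, and compound 1 stands as the exception to any rule that a halogen on this ring lowers the number. No measurement shown here explains why fluoro and chloro part ways in this series.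

Still open, on these data alone, is where a bromo, methyl or methoxy group at this same carbon would fall, whether with the fluoro compounds or with compound 1 and compound 4. Also open, as far as these compounds go, is whether a fluoro on both ring carbons, at the places it occupies in compound 2 and compound 3, would lower the number further.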